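Chloro to bromo: 3-chlorophenyl to 3-bromophenyl

A few compounds are considered here, and "the series" means these few. Any claim that something is new, unique, unknown or untested is made for them only; others in the source may bear on it.

Of the compounds shown here, two have so far been read in a toxicity assay on HaCaT cells (Homo sapiens) for cytotoxicity, read by CCK-8 assay, with a stated time of 24 h; a higher number here means that more compound is tolerated, a lower number that less compound is tolerated. Compound 1 `COc1ccccc1Oc1c(N)nc(-c2ccccc2)nc1Cl` is reported as "not active" (no number reported), with no number attached. Compound 2 `COc1ccccc1Oc1c(N)nc(-c2cccc(Cl)c2)nc1Cl` gives > 80000 nM, which is a limit of the assay and not a number. Compound 2 therefore has no single value in this assay, and its standing is given only by the limit of > 80000 nM in this assay, at which 1 of the 2 values shown sits.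

The next member, compound 3 `COc1ccccc1Oc1c(N)nc(-c2cccc(Br)c2)nc1Cl`, differs from compound 2 by one exchange: bromo in place of chloro on an aromatic carbon. In words, this is bromo in place of chloro on an aromatic carbon, and the same difference reads 3-chlorophenyl to 3-bromophenyl. Going by the values given here, the series offers no measured step between two compounds, so this exchange has no direct precedent here. No change beyond the usual scatter is expected in this assay, and neither direction is favoured. This expectation rests on compound 2, whose reading of > 80000 nM is a limit, and on the chloro-to-bromo exchange itself. The estimated step of a number no higher from compound 2 to compound 3 (the limit leaves the size open) is expected to stay within the scatter. For compound 3 the estimated value is 80000 nM, with an expected range of 40000 nM to 160000 nM.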

Compound 3, half-maximal cytotoxic concentration: 16100 nM
Estimate against measurement, compound 3: 5.0-fold (0.70 log units) above, outside the stated range (below it).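

In this assay, the halogen on an aromatic carbon of the phenyl group, meta to a large group, is not a silent place in the series: bromo in place of chloro gives an at least 4.9-fold lower number from compound 2 to compound 3 (0.69 log units; beyond the scatter). This single-atom exchange brings no change in ring, charge or count of hydrogen-bond donors and acceptors, yet the step lies beyond the scatter, so at this place the identity of the halogen alone is enough to move the reading. Compound 3 is also the first member shown with a single number in this assay, which gives the series a measured reference point, while the size of the step stays open at its upper end because compound 2 is a limit of the assay and not a number: the limit of > 80000 nM in this assay, at which 1 of the 3 values shown sits.

The compounds shown leave open whether the number keeps falling along the halogens, which fluoro and iodo at the same place would test, and whether a non-halogen group such as methyl, an amine or a carboxylic acid is tolerated there. They also leave open whether the same exchange at another position on the phenyl group would give a step of similar size.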